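A few compounds are considered here, and "the series" means these few. Any claim that something is new, unique, unknown or untested is made for them only; others in the source may bear on it.

Measured so far:
compound 1 `COc1cc(-c2cc(/C=C/C(=O)c3ccc(N)cc3)[nH]n2)cc(OC)c1OC`; in a functional assay on PC-3 cells (Homo sapiens) for cytotoxicity, read by sulforhodamine B assay, with a stated time of 48 h, tested at 0.01 uM (a higher number here means a weaker effect of the compound at the concentration tested, a lower number a stronger effect), compound 1 gives 97%
compound 2 `COc1ccc(-c2cc(/C=C/C(=O)c3ccc(OC)c(OC)c3)[nH]n2)cc1`; in this assay compound 2 gives 95%

Of the two numbers shown, compound 1 carries the higher one, but compound 2 lies only slightly lower, a gap within the usual scatter of this assay, so no order between the two can be drawn. Both numbers sit near the top of the scale, meaning that at this concentration neither compound has a clear effect on the cells.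

Going by the values given here, no pair of measured compounds differs in a single place, so there is no measured step to lean on for the next compound.

Compound 3 `COc1cc(-c2cc(/C=C/C(=O)c3ccc(Cl)c(Cl)c3)[nH]n2)cc(OC)c1OC` is the compound to be measured. Relative to compound 1 the change is 3,4-dichlorophenyl in place of 4-aminophenyl on a carbonyl carbon.

Among the compounds with values here, with nothing but the two close numbers of compound 1 and compound 2 as background, and no measured step on this kind of change, the expectation for this assay is a step of no size beyond the scatter, in no particular direction. For compound 3 the estimate in this assay is 96%, with a range from 85% to 103%, which as a step means a number 1 percentage points lower from compound 1 to compound 3 (within the scatter).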

Compound 3, a percentage reported as activity, at one concentration (the size of the read-out at that concentration, not a potency): 95%
Compound 3: middle estimate off by 1 percentage points, on the high side; the range from low to high includes it.
By their numbers in this assay, from the lowest: compounds 2, 3 and 1 (each within the scatter of the next).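

In this assay, going by these compounds alone, 3,4-dichlorophenyl in place of 4-aminophenyl on a carbonyl carbon gives a number 2 percentage points lower from compound 1 to compound 3 (within the scatter) as the first measured step at this position. The exchange removes the hydrogen-bond donor and acceptor counted on 4-aminophenyl and brings in two chlorine atoms, yet the read-out at this one concentration does not separate the two compounds, and compound 3 at 95% stays near the top of the scale, without a clear effect on the cells. No measured evidence bears on the size of this step, so the result carries no explanation with it.

Going by these compounds, with the numbers this near the top of the scale, it remains open whether any group on this carbonyl carbon can move the read-out beyond the scatter, and a carboxylic acid, a dimethylamino group or a longer alkyl chain there would test this. Also open, on these data alone, is whether 4-aminophenyl and 3,4-dichlorophenyl would separate at a higher concentration, where the cells might respond at all.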